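The source may report more compounds than this note shows. Statements on the series, on what has been measured and on what is new or still open speak of the compounds shown alone.

Measured so far:
- compound 1, `COc1cc(/C=C/c2ccc3ccccc3n2)cc(OC)c1OC`: 398 nM
- compound 2, `COc1cc(/C=C\c2ccc3cccnc3c2)cc(OC)c1OC`: 158 nM

In a functional assay on SK-MEL-28 cells (Homo sapiens) for cytotoxicity (a lower number here means a stronger inhibitor, a higher number a weaker inhibitor), compound 2 gives 158 nM, the lowest number of the two measured here. Compound 1 gives 398 nM in this assay, a higher number, and the gap between the two lies beyond the usual scatter. Compound 3, `COc1cc(/C=C/c2ccc3cccnc3c2)cc(OC)c1OC`, has not been measured. It differs from compound 2 as follows: the two compounds have the same atoms and bonds and differ only in configuration as drawn: 1 of 1 stereo elements differ; a double bond is drawn Z in compound 2 and E in compound 3. Going by the values given here, no pair of measured compounds differs in this one place alone, so the size of such a step in this assay is not known from these data; compound 1 differs from compound 3 in another place as well, so it cannot settle the matter. The step from compound 2 to compound 3 is expected to raise the number, that is to weaken the inhibitor, by a 3.8-fold higher number from compound 2 to compound 3 (0.58 log units; beyond the scatter), with wide uncertainty. Compound 3 is expected to give about 600 nM in this assay, somewhere between 150 nM and 2500 nM.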

Compound 3, half-maximal inhibitory concentration: 1580 nM
The estimate for compound 3 lay 2.6-fold (0.42 log units) below the measured number; the range from low to high includes it.
By their numbers in this assay, from the lowest: compound 2; then compound 1; then compound 3.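

Measured in this assay the double bond turns out to matter a great deal, since changing it from Z to E gives a 10-fold higher number from compound 2 to compound 3 (1.00 log units; beyond the scatter) in this pair. No earlier comparison could isolate this change, but now its direction and size can be read directly, with the Z form as the stronger inhibitor of the two. The gap can be assigned to the double bond's configuration and to no other part of the structure: the fact that compounds 2 and 3 differ only in the configuration as drawn.

Going by these compounds, whether Z also beats E on the core of compound 1 stays open, as a single pair cannot show how general this preference is. Also open, on these data alone, is how the number would move if one of the methoxy groups gave way to a hydroxyl group or an amine.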